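This account rests on a few compounds, and the source may have more. Where it says the series, first, only, none or still open, it means among the compounds named here.

Compound 1, `Cc1ccc(C(=O)/C=C/c2ccc3c(c2)B(O)OC3)cc1`: 10500 nM
Compound 2, `Cc1cccc(C(=O)/C=C/c2ccc3c(c2)B(O)OC3)c1`: 6700 nM
Compound 3, `O=C(/C=C/c1ccc2c(c1)B(O)OC2)c1cccc(O)c1`: 6500 nM

Of the compounds shown here, three built on the same core have been tested in a functional assay on HCT-116 cells (Homo sapiens) for cytotoxicity, read by MTT assay, with a stated time of 48 h; a higher number here means a weaker inhibitor, a lower number a stronger inhibitor. Compound 3 returns the lowest of the three numbers, but this stands for little: the step of a 1.6-fold lower number from compound 1 to compound 3 (0.21 log units; within the scatter) is within the scatter, and the step of a 1.0-fold lower number from compound 2 to compound 3 (0.01 log units; within the scatter) is essentially nil. The remaining step, a 1.6-fold lower number from compound 1 to compound 2 (0.20 log units; within the scatter), is likewise within the scatter. Across the three, changing the group on the ring attached to the carbonyl carbon, or moving it, has produced no difference that can be trusted.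

Compound 4, `COCOc1cccc(C(=O)/C=C/c2ccc3c(c2)B(O)OC3)c1`, is the next member. Relative to compound 3 the change is methoxymethyl in place of hydrogen on an oxygen on an aromatic ring. Among the compounds with values here, no measured step touches an oxygen in this way, so the closest guides are the steps that alter the same ring, above all the hydroxy to methyl exchange between compound 2 and compound 3, which was flat. On that basis, only a small step, no change at the digits printed from compound 3 to compound 4 (within the scatter), is expected, with no clear direction. Compound 4 is therefore estimated at 6500 nM, with a plausible range from 3000 nM to 14000 nM.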

Compound 4, half-maximal inhibitory concentration: 13300 nM
For compound 4 the middle estimate is 2.0-fold (0.31 log units) below the measured one; the measured number falls inside the stated range.
By their numbers in this assay, from the lowest: compounds 3, 2, 1 and 4 (each within the scatter of the next, the first and the last beyond it).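

In this assay, within the data shown here, putting methoxymethyl in place of hydrogen on the oxygen on the aromatic ring gives the first step in this short series to lie beyond the scatter, a 2.0-fold higher number from compound 3 to compound 4 (0.31 log units; beyond the scatter), although it is modest. Among these compounds, the earlier changes to this ring, including the exchange of hydroxy and methyl, gave no difference that could be trusted, so this oxygen is the first place where a change registers at all. The reading depends on the comparison, however: when the starting point is the methyl group rather than the hydroxy, the step of a 2.0-fold higher number from compound 2 to compound 4 (0.30 log units; within the scatter) stays within the scatter, so the change stands out only against the hydroxy of compound 3, and it rests on that single pair. The data offered here contain nothing that bears on the reason for this step.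

From the compounds shown here alone, what remains open is whether this step belongs to methoxymethyl itself or would appear with any group on that oxygen, such as a plain methyl or a longer chain ending in an amine. Also open, going by these compounds, is whether a carboxylic acid in place of the hydroxy would move the number further from that of compound 3.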